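The source may report more compounds than this note shows. Statements on the series, on what has been measured and on what is new or still open speak of the compounds shown alone.

Measured compounds in a physicochemical assay for lipophilicity, at pH 7.4; on this read-out higher numbers stand for higher lipophilicity and lower numbers for lower lipophilicity:
Compound 1 `CC(=O)Nc1cc(C)n(Cc2cc(Cl)ccc2OCc2ccccc2)n1` gives > 3.7 in this assay, which is a limit of the assay and not a number.
Compound 2 `Cc1cc(NC(=O)C2CCOCC2)nn1Cc1cc(Cl)ccc1OCc1ccccc1` gives > 3.7 in this assay, again a limit and not a number.
Compound 3 `Cc1cc(NC(=O)c2ccccc2)nn1Cc1cc(Cl)ccc1OCc1ccccc1` gives > 3.7 in this assay, also a limit and not a number.

Compound 3 thus stands where every measured member of the series stands, at the limit of > 3.7 in this assay, at which 3 of the 3 values shown sit. Within the data shown here, the three exchanges on the carbonyl carbon, a step that the two limits leave unreadable from compound 1 to compound 2, a step that the two limits leave unreadable from compound 1 to compound 3 and a step that the two limits leave unreadable from compound 2 to compound 3, give no readable size in this assay, so the series so far offers no scale for how much an exchange at that position moves the read-out.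

Compound 4 `Cc1cc(NC(=O)c2c(F)cccc2F)nn1Cc1cc(Cl)ccc1OCc1ccccc1` carries the change (2,6-difluorophenyl in place of phenyl on a carbonyl carbon). The measured steps bear on it only in one respect: no exchange on the carbonyl carbon, whether to oxan-4-yl or to phenyl, has brought a compound back below the limit, and none of them shows a direction. For compound 4 the step is accordingly expected to remain unreadable, with an estimated step that the limit leaves unreadable from compound 3 to compound 4 that cannot be confirmed as beyond or within the scatter. Compound 4 is expected at 4.3, with a range from 3.8 to 4.9, and is most likely to be returned again as a limit rather than a number.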

Compound 4, distribution coefficient: > 3.7
Compound 4 gave a limit, no number; the forecaster's own chance of this, stated with the estimate: 90%; the middle value is on the limit's open side.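

In this assay compound 4 gives > 3.7, a limit of the assay and not a number. Its steps from compound 1, compound 2 and compound 3 cannot be read, and the series stays in one place: the limit of > 3.7 in this assay, at which 4 of the 4 values shown sit.

The compounds shown leave open how far, and in which direction, any exchange on the carbonyl carbon moves the read-out.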